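Chloro in place of fluoro: an estimate for compound 4

A few compounds are considered here, and "the series" means these few. Any claim that something is new, unique, unknown or untested is made for them only; others in the source may bear on it.

compound 1 `COc1cc(OC)c(-c2coc3cc(OCC=C(C)C)ccc3c2=O)cc1OC`: 1580 nM
compound 2 `COc1cc(OC)c(-c2coc3cc(OCc4ccccc4)ccc3c2=O)cc1OC`: 1640 nM
compound 3 `COc1cc(OC)c(-c2coc3cc(OCc4cccc(F)c4)ccc3c2=O)cc1OC`: 1300 nM

In a functional assay on A-375 cells (Homo sapiens) for antiproliferative activity, read by MTT assay, with a stated time of 24 h (on this read-out lower numbers stand for stronger inhibition and higher numbers for weaker inhibition), compound 3 gives 1300 nM, and it cannot be separated from the other two compounds: the measurements show a 1.2-fold lower number from compound 1 to compound 3 (0.08 log units; within the scatter) and a 1.3-fold lower number from compound 2 to compound 3 (0.10 log units; within the scatter). Compound 4 `COc1cc(OC)c(-c2coc3cc(OCc4cccc(Cl)c4)ccc3c2=O)cc1OC` follows from compound 3 by one exchange, (chloro in place of fluoro on an aromatic carbon), chloro in place of fluoro on an aromatic carbon. Among the measured compounds shown here, no measured step makes this exchange. The closest is a 1.3-fold lower number from compound 2 to compound 3 (0.10 log units; within the scatter), where fluoro replaces hydrogen, and a 1.0-fold higher number from compound 1 to compound 2 (0.02 log units; within the scatter) shows a larger change at the same place. Nothing here points to a shift beyond the scatter in this assay, in either direction. The expected outcome is no change at the digits printed from compound 3 to compound 4 (within the scatter). For compound 4 the estimated value is 1300 nM, with an expected range of 750 nM to 2250 nM.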

Compound 4, half-maximal inhibitory concentration: 980 nM
For compound 4 the middle estimate is 1.3-fold (0.12 log units) above the measured one; the range from low to high includes it.
By their numbers in this assay, from the lowest: compounds 4, 3, 1 and 2 (each within the scatter of the next).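

In this assay, the 3-chlorobenzyl group on the oxygen cannot be told apart from the 3-fluorobenzyl group (a 1.3-fold lower number from compound 3 to compound 4 (0.12 log units; within the scatter)). The two larger exchanges also stay within the scatter, chloro in place of hydrogen (a 1.7-fold lower number from compound 2 to compound 4 (0.22 log units; within the scatter)) and 3-chlorophenyl in place of 2-methylprop-1-en-1-yl (a 1.6-fold lower number from compound 1 to compound 4 (0.21 log units; within the scatter)), so none of the four compounds separates from another at this position. No measurement given here accounts for these steps. As far as these compounds go, it remains open whether an amine or a carboxylic acid on the phenyl ring, or a longer chain, would produce a step beyond the scatter.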